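The compounds below may be only part of what the source reports. "The series", "measured", "known", "first", "only" and "open" are said of these compounds alone.

Three compounds have been measured in an ADME assay on HEL cells (Homo sapiens) for cytotoxicity, with a stated time of 3 days; a higher number here means that more compound is tolerated, a lower number that less compound is tolerated:

Compound 1 `CCCc1ccc(C#Cc2cc3cn([C@H]4C[C@H](O)[C@@H](CO)O4)c(=O)nc3o2)cc1`: > 120000 nM, which is a limit of this assay rather than a number.
Compound 2 `Cc1ccc(C#Cc2cc3cn([C@H]4C[C@H](O)[C@@H](CO)O4)c(=O)nc3o2)cc1`: 510000 nM.
Compound 3 `Cc1ccc(CCc2cc3cn([C@H]4C[C@H](O)[C@@H](CO)O4)c(=O)nc3o2)cc1`: > 540000 nM, again a limit of this assay rather than a number.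

Compound 2 and compound 3 differ in their cores by 2-(4-methylphenyl)ethyl in place of 2-(4-methylphenyl)ethynyl on an aromatic carbon. That change gives an at least 1.0-fold higher number from compound 2 to compound 3 (0.02 log units; that floor lies within the scatter), so the two values show no difference that can be read. Compound 2 and compound 1 differ by ethyl in place of hydrogen on a saturated chain carbon bound to an aromatic carbon. The size of a step that the limit leaves unreadable from compound 2 to compound 1 cannot be read because the limit of > 120000 nM in this assay, at which 1 of the 3 values shown sits, sits in the way.

Compound 4 `CCCc1ccc(CCc2cc3cn([C@H]4C[C@H](O)[C@@H](CO)O4)c(=O)nc3o2)cc1` has not yet been measured. It differs from compound 3 by ethyl in place of hydrogen on a saturated chain carbon bound to an aromatic carbon, the same change, at the same place, as that made between compound 2 and compound 1. With compound 3 already sitting at the limit of > 540000 nM in this assay, at which 1 of the 3 values shown sits, and with the earlier step of this change unreadable, a step of an at least 1.0-fold lower number from compound 3 to compound 4 (0.03 log units; that floor lies within the scatter) is expected, meaning no readable movement. Compound 4 is therefore estimated at about 500000 nM, most likely between 150000 nM and 1500000 nM, and a limit rather than a number is again quite possible.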

Compound 4, half-maximal cytotoxic concentration: > 130000 nM
Compound 4: a limit, no number (the forecaster's own chance of this, stated with the estimate: 75%); the middle value is on the limit's open side.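

For the compounds shown here, compound 3 and compound 4 both stand at limits rather than numbers in this assay, so no step between them can be read. The compounds shown leave open whether 4-propylphenyl in place of 4-methylphenyl changes the half-maximal cytotoxic concentration at all, with either the ethynyl-linked pair, compound 2 and compound 1, or the ethyl-linked pair, compound 3 and compound 4.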